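A few compounds are considered here, and "the series" means these few. Any claim that something is new, unique, unknown or untested is made for them only; others in the source may bear on it.

In an ADME assay on MT4 cells (Homo sapiens) for cytotoxicity, read by MTT assay, with a stated time of 96 h (a lower number here means that less compound is tolerated, a higher number that more compound is tolerated), compound 3 `CCN(CC)CC(=O)Nc1ccc(-c2nc3cc(C(F)(F)F)ccc3[nH]2)cc1` gives 8000 nM, the higher of the two numbers in the set. Its nearest neighbour is compound 1 `O=C(CCl)Nc1ccc(-c2nc3cc(C(F)(F)F)ccc3[nH]2)cc1`, which gives 5000 nM; the step of a 1.6-fold higher number from compound 1 to compound 3 (0.20 log units; within the scatter) is small. Compound 2 `CCC(=O)Nc1ccc(-c2nc3cc(C(F)(F)F)ccc3[nH]2)cc1` reaches only a limit, >= 100000 nM, as noted in the limit of >= 100000 nM in this assay, at which 1 of the 3 values shown sits. Against that limit, an at least 20-fold higher number from compound 1 to compound 2 (1.30 log units; beyond the scatter) and an at least 12-fold lower number from compound 2 to compound 3 (1.09 log units; beyond the scatter) are both large steps.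

Compound 4 `O=[N+]([O-])c1ccc(-c2nc3cc(C(F)(F)F)ccc3[nH]2)cc1` differs from compound 3 by nitro in place of (((diethylamino)methyl)carbonyl)amino on an aromatic carbon. Within the data shown here, all three measured steps change a chloro, methyl or diethylamino on a saturated chain carbon bound to a carbonyl carbon, whereas here the whole (((diethylamino)methyl)carbonyl)amino group leaves and nitro enters; no measured step bears on this change directly. Among the measured compounds shown here, the one compound lacking both chloro and diethylamino at that chain carbon, compound 2, sat at the limit, so a move toward higher numbers in this assay is more likely than the reverse, with wide uncertainty. The estimated step is a 3.8-fold higher number from compound 3 to compound 4 (0.57 log units; beyond the scatter). Compound 4 is accordingly expected to give 30000 nM, within 6000 nM to 150000 nM.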

Compound 4, half-maximal cytotoxic concentration: 6000 nM
Beside the measured number, compound 4's estimate is 5.0-fold (0.70 log units) above it, and the stated range covers the measured number.
By their numbers in this assay, from the lowest: compounds 1, 4 and 3 (each within the scatter of the next). At a limit, above all of these: compound 2.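

At this aromatic carbon, a full acylamino side chain is not needed for the level of tolerance seen in this assay: a 1.3-fold lower number from compound 3 to compound 4 (0.12 log units; within the scatter), and a 1.2-fold higher number from compound 1 to compound 4 (0.08 log units; within the scatter). Nitro, a much smaller group with no hydrogen-bond donor, therefore sits level with both the diethylamino and the chloro side chains. Compound 2, the propanoylamino member, stays apart from compound 4, an at least 16-fold lower number from compound 2 to compound 4 (1.22 log units; beyond the scatter), and its value is a limit: the limit of >= 100000 nM in this assay, at which 1 of the 4 values shown sits.

Among the compounds shown, only the propanoylamino group separates from the rest, leaving open whether this holds for that chain alone or for simple acylamino groups generally. A free amine or an acetylamino group at this aromatic carbon could fall with compound 4 or with compound 2.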